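The source may report more compounds than this note shows. Statements on the series, on what has been measured and on what is new or still open speak of the compounds shown alone.

Measured so far:
compound 1 `COc1cccc(Nc2nc(Oc3cccc(NC(=O)/C=C/C(C)C)c3)c3sccc3n2)c1` — 37100 nM
compound 2 `CCC/C=C/C(=O)Nc1cccc(Oc2nc(Nc3cccc(OC)c3)nc3ccsc23)c1` — 5560 nM
compound 3 `CC(C)/C=C/C(=O)Nc1cccc(Oc2nc(Nc3cccc(C#N)c3)nc3ccsc23)c1` — 19000 nM

All three numbers come from a functional assay on A549 cells (Homo sapiens) for inhibition, read by MTT assay, with a stated time of 72 h; a higher number here means a weaker inhibitor, a lower number a stronger inhibitor. Compound 1 and compound 2 share a core and differ only in the amide chain: propyl in place of isopropyl on a double-bonded chain carbon bound to a double-bonded chain carbon. That change gives a 6.7-fold lower number from compound 1 to compound 2 (0.82 log units; beyond the scatter). Compound 1 and compound 3 differ only in the aryl amine: cyano in place of methoxy on an aromatic carbon. That change gives a 2.0-fold lower number from compound 1 to compound 3 (0.29 log units; within the scatter), so compound 1 and compound 3 cannot be ordered against each other. Compound 3 stands apart from compound 2 by a wider gap, as their two values show.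

Compound 4 `CCC/C=C/C(=O)Nc1cccc(Oc2nc(Nc3cccc(C#N)c3)nc3ccsc23)c1` has not yet been run in this assay. It relates to compound 3 as compound 2 relates to compound 1: propyl in place of isopropyl on a double-bonded chain carbon bound to a double-bonded chain carbon. The place is the same in both pairs, word for word, so this is the same change, carried onto a core that differs from the core of compound 1 by the cyano-for-methoxy swap described above. Among the compounds with values here, only one measured instance of the chain change exists, so how far it carries over is untested; nothing here says the cyano core will respond differently, and nothing proves it will respond the same.

Compound 4 is expected to land near 3500 nM, within roughly 1200 nM to 10000 nM, because the same chain change produced a 6.7-fold lower number from compound 1 to compound 2 (0.82 log units; beyond the scatter). Within the data shown here, the expected step is a 5.4-fold lower number from compound 3 to compound 4 (0.73 log units; beyond the scatter), set slightly smaller than the earlier one to allow for the single precedent.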

Compound 4, half-maximal inhibitory concentration: 16700 nM
For compound 4 the middle estimate is 4.8-fold (0.68 log units) below the measured one, outside the stated range (above it).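

Propyl in place of isopropyl gives a 1.1-fold lower number from compound 3 to compound 4 (0.06 log units; within the scatter) on the cyano core, so in this assay the change does not carry over from the core of compound 1 at the size seen there, and the two cores respond differently: the same change on two cores in this assay, a 6.7-fold lower number (0.82 log units; beyond the scatter) from compound 1 to compound 2 and a 1.1-fold lower number (0.06 log units; within the scatter) from compound 3 to compound 4, 5.9-fold (0.77 log units) apart, beyond the scatter of two such steps.
Read the other way, cyano in place of methoxy gives a 3.0-fold higher number from compound 2 to compound 4 (0.48 log units; beyond the scatter) with the propyl chain, so that swap also depends on the chain it is paired with: the same change on two cores in this assay, a 2.0-fold lower number (0.29 log units; within the scatter) from compound 1 to compound 3 and a 3.0-fold higher number (0.48 log units; beyond the scatter) from compound 2 to compound 4, 5.9-fold (0.77 log units) apart, beyond the scatter of two such steps.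
The two changes therefore do not act independently across these four compounds, but the compounds do not show why, nor whether the gain seen in compound 2 is particular to the methoxy core or would recur on other cores.

Open, as far as these compounds go, is whether a longer chain, such as pent-1-en-1-yl extended by further carbons, follows the large step seen on the methoxy core or the absence of a clear step on the cyano core. Also open, from the compounds shown here alone, is whether another group on the same aromatic carbon, such as chloro or an amine, pairs with the propyl chain as methoxy does or as cyano does.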